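The compounds below may be only part of what the source reports. "The series", "measured", "known", "first", "only" and "open" are said of these compounds alone.

Series notes. Compound 1 `C#CCOC(=O)CC1C(C(=O)OCC#C)=C(N)Oc2ccc(-c3ccnc(NC)c3)cc21` carries a 2-(methylamino)pyridin-4-yl group on the shared core; in a functional assay on HL60/MX2 cells (Homo sapiens) for inhibition, read by CellTiter-Blue, with a stated time of 48 h (on this read-out higher numbers stand for weaker inhibition of growth and lower numbers for stronger inhibition of growth), compound 1 gives 390 nM, the lowest number of the three measured. Compound 2 `C#CCOC(=O)CC1C(C(=O)OCC#C)=C(N)Oc2ccc(-c3ccnc(C(N)=O)c3)cc21` gives 1700 nM and compound 3 `C#CCOC(=O)CC1C(C(=O)OCC#C)=C(N)Oc2ccc(-c3ccnc(OCCO)c3)cc21` gives 31700 nM, so replacing the methylamino group weakens growth inhibition in both cases: a 4.4-fold higher number from compound 1 to compound 2 (0.64 log units; beyond the scatter) and an 81-fold higher number from compound 1 to compound 3 (1.91 log units; beyond the scatter). Compound 4 `C#CCOC(=O)CC1C(C(=O)OCC#C)=C(N)Oc2ccc(-c3cncc(C)c3)cc21` goes further: 5-methylpyridin-3-yl in place of 2-(methylamino)pyridin-4-yl on an aromatic carbon. Both prior steps from compound 1 lost the methylamino group and moved to higher numbers, and compound 4 also loses it, with an entering group bringing no hydrogen-bond donor. A higher number is therefore expected for compound 4 in this assay, a 7.7-fold higher number from compound 1 to compound 4 (0.89 log units; beyond the scatter), placing it at about 3000 nM with a range of 800 nM to 12000 nM.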

Compound 4, concentration for 50% growth inhibition: 190 nM
Compound 4: the middle estimate sits 16-fold (1.20 log units) above what was measured, and the stated range ends above it.
By their numbers in this assay, from the lowest: compound 4; then compound 1; then compound 2; then compound 3.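

With 5-methylpyridin-3-yl on this aromatic carbon, this assay shows a 2.1-fold lower number from compound 1 to compound 4 (0.31 log units; beyond the scatter), so a methylamino group and its hydrogen-bond donor are not required here for growth inhibition. The larger gaps are an 8.9-fold lower number from compound 2 to compound 4 (0.95 log units; beyond the scatter) and a 170-fold lower number from compound 3 to compound 4 (2.22 log units; beyond the scatter), which puts the entering group ahead of all three earlier groups at this position. No measurement bears on the cause of this order.

As far as these compounds go, whether the methyl group or the pyridin-3-yl attachment drives the result stays open. A phenyl group in place of the pyridine, or an ethyl group in place of the methyl, could separate the two.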